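Hydroxy in place of hydrogen on compound 1

The source may hold more compounds than are shown below. What is called first, only, known or untested is meant among the compounds shown, and "the series" means these compounds.

Measured so far in a physicochemical assay for lipophilicity, read by HPLC, measured as octanol-water partition (a lower number here means a more polar compound, a higher number a more lipophilic compound), as follows:
- compound 1 `O=C(N/N=C/c1ccc2no[n+]([O-])c2c1)c1ccccc1` gives 2.2
- compound 2 `CC(C)(C)c1ccc(C(=O)N/N=C/c2ccc3no[n+]([O-])c3c2)cc1` gives 3.8

Going by the values given here, compound 1 holds the lower of the two numbers, and the only measured step is a number 1.60 log units higher from compound 1 to compound 2 (beyond the scatter) with tert-butyl in place of hydrogen on an aromatic carbon. The unmeasured compound 3 `O=C(N/N=C/c1ccc2no[n+]([O-])c2c1)c1cccc(O)c1` carries a different change, hydroxy in place of hydrogen on an aromatic carbon in the form of hydroxy in place of hydrogen on an aromatic carbon, meta to a large group. Cut one bond further out, this reads phenyl to 3-hydroxyphenyl. Among the compounds with values here, the tert-butyl step is the sole guide. Within the data shown here, it shows that one substitution on an aromatic carbon can shift this assay by a large amount, but no measured compound carries hydroxy, so it fixes neither size nor direction here. Judged from the structural change alone, a moderate downward move is expected, and the estimated step is a number 0.50 log units lower from compound 1 to compound 3 (beyond the scatter) in size well short of the tert-butyl step. In this assay compound 3 is estimated at 1.7 with an expected range from 1.2 to 2.2 as its two ends.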

Compound 3, partition coefficient: 1.2
Compound 3: the middle estimate sits 0.50 log units above what was measured; the range from low to high includes it.
By their numbers in this assay, from the lowest: compound 3; then compound 1; then compound 2.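

In this assay, hydroxy in place of hydrogen on an aromatic carbon, meta to a large group, gives a number 1.00 log units lower from compound 1 to compound 3 (beyond the scatter), the first downward step measured from compound 1. Set against a number 1.60 log units higher from compound 1 to compound 2 (beyond the scatter), this shows that single substitutions on the phenyl of compound 1 can move the number in either direction, so compound 1 no longer marks the low end of the series and the hydroxy step is smaller than the tert-butyl step. No measurement in hand explains the direction or size of the hydroxy step.

The compounds shown leave open whether hydroxy gives a similar step at another carbon of the phenyl or on a parent other than compound 1, since this change is seen only once, at one position. They also leave open how other groups at this same place compare with hydroxy, for example an amine, a carboxylic acid or methoxy, and whether any of these would land nearer to compound 3 or to compound 1 on this scale.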